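The compounds below may be only part of what the source reports. "The series", "measured", "known", "first", "only" and "open" are said of these compounds alone.

Compound 1 `CCCNc1nc2ccccc2c(NCc2ccc(NC(=O)c3ccc(F)cc3)cc2)c1C#N`: > 20000 nM
Compound 2 `CNc1nc(NCc2ccc(NS(=O)(=O)c3ccc(F)cc3)cc2)c2ccccc2n1`: 5300 nM
Compound 3 `Cc1ccc(S(=O)(=O)Nc2ccc(CNc3nc(N(C)C)nc4ccccc34)cc2)cc1`: 11000 nM

Of the compounds shown here, three have been tested in a functional assay on HCT-116 cells (Homo sapiens) for inhibition, read by luminescence and resazurin assay, with a stated time of 3 days; on this read-out lower numbers stand for stronger inhibition and higher numbers for weaker inhibition. The value for compound 1, > 20000 nM, is a limit of the assay and not a number. Of the two compounds with numbers, compound 3 has the higher one at 11000 nM, and compound 2 sits at 5300 nM; the gap between these two lies beyond the usual scatter of the measurement, so compound 2 is the stronger inhibitor of the pair. Compound 1 is also built on a core that differs from the shared core of compound 2 and compound 3, so it does not stand beside them directly.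

Compound 4 `CN(C)c1nc(NCc2ccc(NC(=O)c3ccncc3)cc2)c2ccccc2n1` has not yet been measured. It differs from compound 3 in one place: (pyridin-4-yl)carbonyl in place of (4-methylphenyl)sulfonyl on a nitrogen on an aromatic ring. Among the measured compounds shown here, with no measured pair showing the same kind of change, the expectation rests only on the weak numbers seen so far, and the step from compound 3 to compound 4 in this assay is expected to be a 1.4-fold higher number from compound 3 to compound 4 (0.13 log units; within the scatter), without a clear direction beyond the scatter. Compound 4 is thus estimated to give about 15000 nM in this assay, within a range from 5000 nM to 40000 nM.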

Compound 4, half-maximal inhibitory concentration: 15000 nM
For compound 4 middle estimate and measured number coincide at the digits printed, and the stated range covers the measured number.
By their numbers in this assay, from the lowest: compound 2; then compounds 3 and 4 (each within the scatter of the next). At a limit, above all of these: compound 1.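

Among the compounds shown here, replacing (4-methylphenyl)sulfonyl with (pyridin-4-yl)carbonyl on a nitrogen on an aromatic ring gives the first single-place comparison in this assay: a 1.4-fold higher number from compound 3 to compound 4 (0.13 log units; within the scatter). At this position, then, a sulfonyl link with a carbon-only ring and a carbonyl link with a ring holding a hetero atom cannot be told apart in this assay, and neither compound becomes a strong inhibitor. The upper end of the readable scale is set by compound 1, whose value is a limit and not a number: the limit of > 20000 nM in this assay, at which 1 of the 4 values shown sits.

From the compounds shown here alone, whether a group without an aromatic ring, such as acetyl or a short chain ending in an amine, would move the number from this nitrogen remains open. Going by these compounds, it is also open whether the same exchange would read alike with the other substituent on the shared core in compound 2.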